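The source may report more compounds than this note shows. Statements on the series, on what has been measured and on what is new or still open speak of the compounds shown alone.

In a functional assay on A549 cells (Homo sapiens) for antiproliferative activity, read by MTT assay, with a stated time of 72 h (on this read-out higher numbers stand for weaker inhibition and lower numbers for stronger inhibition), the measured set stands as follows:

- compound 1 `O=C1O[C@H]([C@@H](O)Cn2cc(-c3cccc(O)c3)nn2)C(OCc2ccccc2)=C1OCc1ccccc1`: 59900 nM
- compound 2 `C[Si](C)(C)c1cn(C[C@H](O)[C@H]2OC(=O)C(OCc3ccccc3)=C2OCc2ccccc2)nn1`: 19200 nM
- compound 3 `O=C1O[C@H]([C@@H](O)Cn2cc(CCO)nn2)C(OCc2ccccc2)=C1OCc1ccccc1`: > 100000 nM, a limit of the assay rather than a number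

Compound 3 therefore sits at the limit of > 100000 nM in this assay, at which 1 of the 3 values shown sits, and is the weakest point on the numbers shown; its result tells only that the true value lies beyond that bound.

Compound 4 `COc1ccccc1-c1cn(C[C@H](O)[C@H]2OC(=O)C(OCc3ccccc3)=C2OCc2ccccc2)nn1` differs from compound 3 by 2-methoxyphenyl in place of 2-hydroxyethyl on an aromatic carbon. For the measured compounds named here, two measured steps bear on this change, both ending at compound 3: an at least 1.6-fold higher number from compound 1 to compound 3 (0.22 log units; that floor lies within the scatter) and an at least 5.2-fold higher number from compound 2 to compound 3 (0.71 log units; beyond the scatter). Both steps replace a larger group on that aromatic carbon with 2-hydroxyethyl and both raise the number, the second clearly beyond the scatter. The step to compound 4 runs the other way, bringing back a six-membered aromatic ring as in compound 1, so a lower number than the bound of compound 3 is expected in this assay, of a size near the reverse of the step from compound 1. Compound 4 is thus estimated at 50000 nM (range 15000 nM to 150000 nM), a step of an at least 2.0-fold lower number from compound 3 to compound 4 (0.30 log units; that floor lies within the scatter), with some chance that only a limit is again reported.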

Compound 4, half-maximal inhibitory concentration: > 100000 nM
Compound 4 was reported as a limit; the forecaster's own chance of this, stated with the estimate: 25%; middle value at least 2.0-fold (0.30 log units) away from the limit.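

In this assay compound 4 stands at a limit, not a number, and no step to it from compound 3 can be read: the limit of > 100000 nM in this assay, at which 2 of the 4 values shown sit.

A six-membered aromatic ring of carbon only on this aromatic carbon therefore does not by itself bring a reading inside the assay's range, and the swap of 3-hydroxyphenyl for 2-methoxyphenyl gives an at least 1.6-fold higher number from compound 1 to compound 4 (0.22 log units; that floor lies within the scatter). Trimethylsilyl keeps a clear lead over 2-methoxyphenyl, with an at least 5.2-fold higher number from compound 2 to compound 4 (0.71 log units; beyond the scatter).

Going by these compounds, whether silicon itself matters remains open, and tert-butyl, the all-carbon counterpart of trimethylsilyl, would address that. Also open, on these data alone, is how unsubstituted phenyl, an aminoalkyl chain or a carboxylic acid on this aromatic carbon would read in this assay, and whether any of them would give a number rather than a limit.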